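The source may report more compounds than this note shows. Statements on the series, on what has been measured and on what is new or still open speak of the compounds shown alone.

Compound 1 `COc1cc(-c2nnc(SCc3ccccc3)n2/N=C/c2ccccc2)cc(OC)c1OC`: in a functional assay on MCF7 cells (Homo sapiens) for cytotoxicity, read by MTT assay, with a stated time of 48 h (on this read-out lower numbers stand for stronger inhibition and higher numbers for weaker inhibition), compound 1 gives > 200000 nM, which is a limit of the assay.
Compound 2 `COc1cc(-c2nnc(SCc3ccccc3Cl)n2/N=C/c2ccccc2)cc(OC)c1OC`: in this assay compound 2 gives > 200000 nM, likewise a limit of the assay.

Compound 2 therefore stands at the limit, where both measured values sit (the limit of > 200000 nM in this assay, at which 2 of the 2 values shown sit). Within the data shown here, the one measured step, a step that the two limits leave unreadable from compound 1 to compound 2, chloro in place of hydrogen on an aromatic carbon, cannot be read in size, as both ends are limits. Compound 3 `COc1ccc(/C=N/n2c(SCc3ccccc3Cl)nnc2-c2cc(OC)c(OC)c(OC)c2)c(OC)c1` differs from compound 2 by 2,4-dimethoxyphenyl in place of phenyl on a carbon with a double bond to nitrogen, a 2,4-dimethoxyphenyl in place of phenyl on a carbon with a double bond to nitrogen. Among the measured compounds shown here, no measured step touches this part of the molecule, so the expectation rests only on the two measured compounds both sitting at the limit. Compound 3 is thus expected to give about 200000 nM, in the range 60000 nM to 600000 nM, most likely reported again as a limit. The estimated step of a number no higher from compound 2 to compound 3 (the limit leaves the size open) is expected to be none beyond the scatter.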

Compound 3, half-maximal inhibitory concentration: 63700 nM
Estimate against measurement, compound 3: 3.1-fold (0.50 log units) above; low and high end bracket the measured number.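

In this assay, 2,4-dimethoxyphenyl in place of phenyl on a carbon with a double bond to nitrogen gives an at least 3.1-fold lower number from compound 2 to compound 3 (0.49 log units; beyond the scatter), which shows that the read-out responds to a change at this position. Compound 3 is the only compound shown that gives a number rather than a limit, so the step has one open end and its full size cannot be read. The other two compounds stay at the limit: the limit of > 200000 nM in this assay, at which 2 of the 3 values shown sit.

The compounds shown leave open whether one methoxy group alone would give this step, and whether an amine or a carboxylic acid on this ring would move the number further. They also leave open what chloro in place of hydrogen does when 2,4-dimethoxyphenyl is present, as the earlier step between two limits cannot be read.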